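The compounds below may be only part of what the source reports. "The series", "measured", "known", "first", "only" and "open" are said of these compounds alone.

Measured compounds, in an assay on isolated protein for displacement of a labelled ligand from Gonadotropin-releasing hormone receptor (Homo sapiens); a lower number here means a stronger inhibitor, a higher number a weaker inhibitor:
compound 1, `Cn1cnc(CN2CCN(c3cccc4[nH]c(-c5ccc(C(C)(C)C)cc5)nc34)CC2)c1`: 33 nM
compound 2, `CCc1nc(C)c(CN2CCN(c3cccc4[nH]c(-c5ccc(C(C)(C)C)cc5)nc34)CC2)o1`: 37 nM
compound 3, `CCc1nc(C)c(CN2CCN(c3cccc4[nH]c(-c5ccc(C(C)(C)C)cc5)nc34)CC2)s1`: 20 nM

Compound 1 stands second highest of the three numbers. Its nearest neighbour is given by a 1.1-fold higher number from compound 1 to compound 2 (0.05 log units; within the scatter); its furthest by a 1.7-fold lower number from compound 1 to compound 3 (0.22 log units; within the scatter). The third pairing, a 1.9-fold lower number from compound 2 to compound 3 (0.27 log units; within the scatter), is likewise within the scatter, so the three five-membered rings at this position are not separated by the data.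

Compound 4, `Cc1nc(CN2CCN(c3cccc4[nH]c(-c5ccc(C(C)(C)C)cc5)nc34)CC2)c(C)s1`, remains to be measured in this assay. Relative to compound 1 the change is 2,5-dimethyl-1,3-thiazol-4-yl in place of 1-methyl-1H-imidazol-4-yl on a saturated chain carbon bound to an amine nitrogen in a ring.

Going by the values given here, the steps that bear on it are the two that already place a thiazole at this position: a 1.7-fold lower number from compound 1 to compound 3 (0.22 log units; within the scatter) and a 1.9-fold lower number from compound 2 to compound 3 (0.27 log units; within the scatter), both within the scatter, with the oxazole step a 1.1-fold higher number from compound 1 to compound 2 (0.05 log units; within the scatter) also within it. Compound 4 carries the thiazole with a different arrangement of its methyl groups and attachment, for which no direct comparison exists. The expectation is therefore no step beyond the scatter, leaning if anything toward a lower number as seen for compound 3.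

Compound 4 is estimated at 25 nM in this assay, with a range of 10 nM to 65 nM. This estimate means a 1.3-fold lower number from compound 1 to compound 4 (0.12 log units; within the scatter).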

Compound 4, half-maximal inhibitory concentration: 21 nM
Compound 4: the middle estimate sits 1.2-fold (0.08 log units) above what was measured, and the stated range covers the measured number.
By their numbers in this assay, from the lowest: compounds 3, 4, 1 and 2 (each within the scatter of the next).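

In this assay, the 2,5-dimethyl-1,3-thiazol-4-yl group gives a 1.6-fold lower number from compound 1 to compound 4 (0.20 log units; within the scatter) and a 1.8-fold lower number from compound 2 to compound 4 (0.25 log units; within the scatter), while the comparison with the other thiazole gives a 1.1-fold higher number from compound 3 to compound 4 (0.02 log units; within the scatter), with all three steps within the scatter. The position on a saturated chain carbon bound to an amine nitrogen in a ring therefore now accepts a second thiazole pattern: 2,5-dimethyl-1,3-thiazol-4-yl and 2-ethyl-4-methyl-1,3-thiazol-5-yl are not separated, so the arrangement of the thiazole and its alkyl groups has no readable effect across this pair. No supporting data bear on this result.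

The compounds shown leave open whether the methyl and ethyl groups on these rings contribute at all, since an unsubstituted 1,3-thiazol-4-yl group would be needed to test that. They also leave open whether this position responds to anything outside five-membered aromatic rings with two hetero atoms, such as a phenyl, a pyridin-2-yl, a saturated tetrahydropyran-4-yl or a group carrying a carboxylic acid.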